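Isopropylamino in place of methyl on a carbonyl carbon

The source may hold more compounds than are shown below. What is called first, only, known or untested is meant among the compounds shown, and "the series" means these compounds.

Measured so far in a functional assay with Oryctolagus cuniculus as the target; a lower number here means a stronger inhibitor, a higher number a weaker inhibitor:
- Compound 1 `COc1ccc(-c2nc(/N=C(\N)NC(C)C)sc2-c2ccc(OC)cc2)cc1` gives > 100 nM as a limit
- Compound 2 `COc1ccc(-c2nc(CNC(C)=O)sc2-c2ccc(OC)cc2)cc1` gives 15 nM as a number

For the measured compounds named here, compound 2 stands at 15 nM as the only exact number so far. For compound 1 the result > 100 nM is a limit and not a number.

Compound 3 `COc1ccc(-c2nc(CNC(=O)NC(C)C)sc2-c2ccc(OC)cc2)cc1` comes from compound 2 by a single change, (isopropylamino in place of methyl on a carbonyl carbon), with isopropylamino in place of methyl on a carbonyl carbon. Going by the values given here, no measured step tests this exact swap. The closest evidence is an at least 6.6-fold lower number from compound 1 to compound 2 (0.82 log units; beyond the scatter), where one side chain on the shared core replaces another. Compound 1, the weaker side of that step, carries an isopropyl end, as compound 3 will, while compound 2 has none. With one step and one limit, this is only a weak hint, but it points toward a higher number in this assay and so a weaker inhibitor. The expected change is modest, a 2.3-fold higher number from compound 2 to compound 3 (0.37 log units; beyond the scatter), and it may not clear the scatter by much. Compound 3 is estimated at 35 nM, with an expected range from 8 nM to 150 nM.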

Compound 3, half-maximal inhibitory concentration: 42 nM
The estimate for compound 3 lay 1.2-fold (0.08 log units) below the measured number, and the stated range covers the measured number.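

In this assay, putting isopropylamino in place of methyl on the carbonyl carbon, which turns acetamidomethyl into ((isopropylcarbamoyl)amino)methyl, gives a 2.8-fold higher number from compound 2 to compound 3 (0.45 log units; beyond the scatter), so this position accepts the change at a modest cost and compound 3 remains a clearly measurable inhibitor. An isopropyl end alone therefore does not mark the weak side of this small set, as the side chain of compound 3 also carries one and still gives an at least 2.3-fold lower number from compound 1 to compound 3 (0.37 log units; beyond the scatter). Compound 1 is known only as a limit and not as a number, so that last step has a lower bound on its size and no upper one: the limit of > 100 nM in this assay, at which 1 of the 3 values shown sits.

The swap brings in the amino nitrogen and the isopropyl carbons together, and the compounds shown do not separate what each contributes to the step. A methylamino group or a plain ethyl chain on the same carbonyl carbon would begin to tell the two apart, and a cyclopropylamino group or a longer chain would show whether the number keeps rising as the group grows.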